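Swapping the sulfur-linked ring in a cytotoxic series

The source may report more compounds than this note shows. Statements on the series, on what has been measured and on what is new or still open speak of the compounds shown alone.

Measured compounds:
Compound 1 `Cc1ccc2oc(SCC(=O)Nc3ccc(-c4nc(-c5ccccc5)c(-c5ccccc5)n4C)cc3)nc2c1` gives 1.9% in a functional assay on MCF7 cells (Homo sapiens) for cytotoxicity, read by MTT assay, with a stated time of 24 h, tested at 1.6 ug/mL; a higher number here means a stronger effect of the compound at the concentration tested, a lower number a weaker effect.
Compound 2 `Cn1c(-c2ccc(NC(=O)CSc3nc4ccccc4s3)cc2)nc(-c2ccccc2)c1-c1ccccc1` gives 2.1% in this assay.
Compound 3 `Cn1cnnc1SCC(=O)Nc1ccc(-c2nc(-c3ccccc3)c(-c3ccccc3)n2C)cc1` gives 42.8% in this assay.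

Three compounds share one core and differ only in the ring that hangs on a sulfur. Compound 3 stands highest of the three in this assay: its nearest neighbour is compound 2, and compound 1 lies furthest. The two steps leading to it are both large: a number 40.9 percentage points higher from compound 1 to compound 3 (beyond the scatter) and a number 40.7 percentage points higher from compound 2 to compound 3 (beyond the scatter). The step between the two low compounds is small: a number 0.2 percentage points higher from compound 1 to compound 2 (within the scatter).

Compound 4 `Cn1c(-c2ccc(NC(=O)CSC3=NCCS3)cc2)nc(-c2ccccc2)c1-c1ccccc1` has not yet been measured. It differs from compound 3 in one place: a group of 5 heavy atoms (3 carbon, 1 nitrogen, 1 sulfur; one five-membered non-aromatic ring with 2 hetero atoms) in place of a group of 6 heavy atoms (3 carbon, 3 nitrogen; one five-membered aromatic ring with 3 hetero atoms), on a sulfur. The entering group is again small, not a fused two-ring system as in compound 1 and compound 2, but it is non-aromatic and carries fewer hetero atoms than the group it replaces. For the measured compounds named here, no measured step shows such a change directly. The steps from compound 1 and compound 2 to compound 3 show that this position can move the read-out strongly, so a sizeable drop from compound 3 is possible, yet the small size of the new group leaves room for it to stay nearer compound 3. For compound 4 a value of 24% is expected, within a range from 3% to 50%. That expectation corresponds to an estimated step of a number 18.8 percentage points lower from compound 3 to compound 4 (beyond the scatter).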

Compound 4, a percentage reported as activity, at one concentration (the size of the read-out at that concentration, not a potency): 16.2%
Estimate against measurement, compound 4: 7.8 percentage points above; the range from low to high includes it.
By their numbers in this assay, from the lowest: compounds 1 and 2 (each within the scatter of the next); then compound 4; then compound 3.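

In this assay, the five-membered non-aromatic ring on the sulfur takes away part of the read-out, a number 26.6 percentage points lower from compound 3 to compound 4 (beyond the scatter), yet it still stands clear of the two fused ring systems, a number 14.1 percentage points higher from compound 2 to compound 4 (beyond the scatter) and a number 14.3 percentage points higher from compound 1 to compound 4 (beyond the scatter). This position therefore gives more than a high and a low level, and among these four compounds a small ring is not enough to reach the level of compound 3, although both small rings lie above both fused systems. Nothing available here explains why these ring changes move the read-out as they do.

Compound 4 differs from compound 3 both in losing the aromatic ring and in the make-up of its hetero atoms, and these two changes cannot be told apart with the compounds shown. Also open, going by these compounds, is how the read-out would respond to a 1,3,4-oxadiazol-2-yl ring, which is aromatic but holds an oxygen, or to a plain ethyl chain on the sulfur, which has no ring at all.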